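Methyl on the alkyne phenyl with an isopropyl lactam

The source may report more compounds than this note shows. Statements on the series, on what has been measured and on what is new or still open speak of the compounds shown alone.

Measured compounds:
Compound 1, `Cc1ccccc1C#Cc1ccc2c(n1)CCN(C)C2=O`, gives 776 nM in a functional assay on HEK293 cells for negative allosteric modulation of metabotropic glutamate receptor 5 (Homo sapiens), read by FLIPR and calcium flux; on this read-out higher numbers stand for weaker inhibition and lower numbers for stronger inhibition.
Compound 2, `CN1CCc2nc(C#Cc3ccccn3)ccc2C1=O`, gives 184 nM in this assay.
Compound 3, `CC(C)N1CCc2nc(C#Cc3ccccc3)ccc2C1=O`, gives 706 nM in this assay.

Compound 3 sits within the scatter of compound 1 and is separated from compound 2 by a gap beyond the scatter. Among the compounds with values here, the one step that can be read directly, a 4.2-fold lower number from compound 1 to compound 2 (0.63 log units; beyond the scatter), concerns the group on the triple-bonded carbon, not the lactam substituent. Compound 4, `Cc1ccccc1C#Cc1ccc2c(n1)CCN(C(C)C)C2=O`, differs from compound 3 by methyl in place of hydrogen on an aromatic carbon. Within the data shown here, no measured pair isolates this change: compound 1 carries the same 2-methylphenyl but a methyl rather than isopropyl on the lactam nitrogen, and its value and that of compound 3 lie within the scatter of each other. Among the measured compounds shown here, that comparison is the only guide, and it points to no shift beyond the scatter. The step from compound 3 to compound 4 is therefore expected to be a 1.0-fold lower number from compound 3 to compound 4 (0.00 log units; within the scatter). Compound 4 is estimated at 700 nM in this assay, with a range from 300 nM to 1700 nM.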

Compound 4, half-maximal inhibitory concentration: 810 nM
Beside the measured number, compound 4's estimate is 1.2-fold (0.06 log units) below it; the measured number falls inside the stated range.
By their numbers in this assay, from the lowest: compound 2; then compounds 3, 1 and 4 (each within the scatter of the next).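

Within the data shown here, compound 4 isolates the methyl on the aromatic carbon for the first time: in this assay the phenyl to 2-methylphenyl change gives a 1.1-fold higher number from compound 3 to compound 4 (0.06 log units; within the scatter) and so does not separate the two compounds. It also isolates the group on the amide-type nitrogen in a ring, since with 2-methylphenyl held constant, isopropyl in place of methyl gives a 1.0-fold higher number from compound 1 to compound 4 (0.02 log units; within the scatter) and likewise leaves the value within the scatter. No independent evidence bears on why either change leaves the value within the scatter.

The compounds shown leave open whether pyridin-2-yl, present only in compound 2, would keep its lower number with isopropyl on the ring nitrogen. They also leave open how a methoxy group or a fluorine on that aromatic carbon, or a longer chain on that nitrogen, would read in this assay as the assay's values go.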